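A few compounds are considered here, and "the series" means these few. Any claim that something is new, unique, unknown or untested is made for them only; others in the source may bear on it.

Measured in a functional assay on HCT-116 cells (Homo sapiens) for inhibition, read by MTT assay, with a stated time of 72 h; on this read-out lower numbers stand for stronger inhibition and higher numbers for weaker inhibition:
- Compound 1 `COc1cc(OC)cc(N2CCN(C(=O)c3oc(C)nc3-c3ccccc3F)CC2)c1`: 26 nM
- Compound 2 `COc1cc(OC)cc(N2CCN(C(=O)c3oc(C)nc3-c3ccc(F)cc3)CC2)c1`: 404 nM
- Compound 3 `Cc1nc(-c2cccc(F)c2)c(C(=O)N2CCN(c3cc(Cl)cc(Cl)c3)CC2)o1`: 366 nM

The values of compound 2 and compound 3 lie within the scatter of each other, and compound 1 lies clearly lower than both in this assay.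

Compound 4 `COc1cc(OC)cc(N2CCN(C(=O)c3oc(C)nc3-c3cccc(F)c3)CC2)c1` follows from compound 3 by one change: 3,5-dimethoxyphenyl in place of 3,5-dichlorophenyl on an amine nitrogen in a ring. Going by the values given here, no measured step makes this swap directly. The nearest evidence is a 16-fold higher number from compound 1 to compound 2 (1.19 log units; beyond the scatter), a large step between two compounds that already carry 3,5-dimethoxyphenyl. Compound 4 shares that group but has a different fluorophenyl from both, so its value is expected to fall within or near the span of compound 1 at 26 nM and compound 2 at 404 nM. A moderate move to a lower number is therefore expected, estimated as a 3.1-fold lower number from compound 3 to compound 4 (0.48 log units; beyond the scatter). For compound 4 the estimated value in this assay is 120 nM, with an expected range from 35 nM to 420 nM.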

Compound 4, half-maximal inhibitory concentration: 216 nM
Estimate against measurement, compound 4: 1.8-fold (0.26 log units) below, within the range that was stated.
By their numbers in this assay, from the lowest: compound 1; then compounds 4, 3 and 2 (each within the scatter of the next).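

In this assay, 3,5-dimethoxyphenyl in place of 3,5-dichlorophenyl on an amine nitrogen in a ring gives a 1.7-fold lower number from compound 3 to compound 4 (0.23 log units; within the scatter), so with 3-fluorophenyl present this swap does not stand out from the scatter. Among the 3,5-dimethoxyphenyl compounds, the fluorophenyl change gives a 1.9-fold lower number from compound 2 to compound 4 (0.27 log units; within the scatter) and an 8.3-fold higher number from compound 1 to compound 4 (0.92 log units; beyond the scatter), which leaves the 3-fluorophenyl and 4-fluorophenyl compounds indistinguishable and sets only the 2-fluorophenyl compound apart. Nothing available here accounts for these differences.

It remains open whether 2-fluorophenyl would give a similarly low number alongside 3,5-dichlorophenyl, since that pairing is absent from the compounds shown. As far as these compounds go, it is also open whether the low number of compound 1 26 nM is specific to fluorine, or would hold with a 2-chlorophenyl or 2-methoxyphenyl group on the shared core.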